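A few compounds are considered here, and "the series" means these few. Any claim that something is new, unique, unknown or untested is made for them only; others in the source may bear on it.

Working notes on the series. In an ADME assay on MCF-10A cells (Homo sapiens) for cytotoxicity, read by MTT assay, with a stated time of 72 h (on this read-out lower numbers stand for stronger inhibition of growth and higher numbers for weaker inhibition of growth), compound 1 `CS/C(=N\C(=O)c1ccno1)NC(=O)c1ccno1` returns only a limit, > 100000 nM. Compound 2 `O=C(/N=C(/NC(=O)c1ccno1)[Se]Cc1ccccc1)c1ccno1` also returns a limit in this assay, > 100000 nM. Compound 3 `O=C(/N=C(/NC(=O)c1cccs1)[Se]Cc1ccccc1)c1cccs1` likewise sits at a limit in this assay, > 100000 nM. The change from compound 2 to compound 1 is a group of 2 heavy atoms (1 carbon, 1 sulfur; no ring) in place of a group of 8 heavy atoms (7 carbon, 1 selenium; one six-membered aromatic ring of carbon only), on a carbon with a double bond to nitrogen; the step it made, a step that the two limits leave unreadable from compound 2 to compound 1, cannot be sized because of the limit of > 100000 nM in this assay, at which 3 of the 3 values shown sit. The core of compound 3 differs from the core of compound 2, but the difference between the two cores is not broken down here. Compound 4 `CS/C(=N\C(=O)c1cccs1)NC(=O)c1cccs1` carries the same change relative to compound 3: a group of 2 heavy atoms (1 carbon, 1 sulfur; no ring) in place of a group of 8 heavy atoms (7 carbon, 1 selenium; one six-membered aromatic ring of carbon only), on a carbon with a double bond to nitrogen. Among the compounds with values here, the expected step from compound 3 to compound 4 in this assay is a step that the limit leaves unreadable from compound 3 to compound 4, resting on compound 3 at > 100000 nM and on the one measured instance of this change being unreadable. Compound 4 is expected in this assay at 150000 nM, within 60000 nM to 400000 nM.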

Compound 4, concentration for total growth inhibition: 55100 nM
For compound 4 the middle estimate is 2.7-fold (0.43 log units) above the measured one; the measured number lies below the stated range.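

In this assay, putting methylsulfanyl in place of the selenium-bearing group on the core of compound 3 gives an at least 1.8-fold lower number from compound 3 to compound 4 (0.25 log units; that floor lies within the scatter). This is only a floor, so the step is not shown to go beyond the usual scatter, and its true size stays open. The same change on the core of compound 2 cannot be read, so nothing shows whether the change carries from one core to the other, because both of its ends sit at a limit: the limit of > 100000 nM in this assay, at which 3 of the 4 values shown sit.

The compounds shown leave open what an amine or a longer chain on this carbon, with its double bond to nitrogen, would give in this assay. Also open, as far as these compounds go, is how the change behaves on any core other than these two.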